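The source may hold more compounds than are shown below. What is called first, only, known or untested is meant among the compounds shown, and "the series" means these compounds.

Compound 1 `COc1cc2cc(Oc3ccc(NC(=O)Nc4ccccc4)cc3)c(C)nc2cc1OC` bears an unsubstituted phenyl on the urea, and in a functional assay on SNB-75 cells (Homo sapiens) for inhibition, read by sulforhodamine B assay, with a stated time of 48 h, tested at 10 uM (a lower number here means a stronger effect, a higher number a weaker effect of the compound at the concentration tested), compound 1 gives 75.8%. Compound 2 `COc1cc2cc(Oc3ccc(NC(=O)Nc4ccc(C)cc4)cc3)c(C)nc2cc1OC` gives 56.3% in this assay and stands second highest of the three numbers, the step of a number 19.5 percentage points lower from compound 1 to compound 2 (beyond the scatter) separating it from the top. Compound 3 `COc1cc2cc(Oc3ccc(NC(=O)Nc4cccc(C(F)(F)F)c4)cc3)c(C)nc2cc1OC` gives 13.1%, the lowest of the three, reached by the steps of a number 62.7 percentage points lower from compound 1 to compound 3 (beyond the scatter) and a number 43.2 percentage points lower from compound 2 to compound 3 (beyond the scatter).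

Compound 4 `COc1cc2cc(Oc3ccc(NC(=O)Nc4ccc(Cl)c(Cl)c4)cc3)c(C)nc2cc1OC` is not yet measured. It differs from compound 2 in one place: 3,4-dichlorophenyl in place of 4-methylphenyl on an amide-type nitrogen. The step that bears most directly on it is the exchange of the aryl group on the amide-type nitrogen, a number 43.2 percentage points lower from compound 2 to compound 3 (beyond the scatter), which was large; the two steps from compound 1, a number 19.5 percentage points lower from compound 1 to compound 2 (beyond the scatter) and a number 62.7 percentage points lower from compound 1 to compound 3 (beyond the scatter), both also ran downward. A downward step of large size is therefore expected in this assay, namely a number 31.3 percentage points lower from compound 2 to compound 4 (beyond the scatter). The estimate for compound 4 is 25%, with a range from 8% to 50%.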

Compound 4, a percentage reported as activity, at one concentration (the size of the read-out at that concentration, not a potency): 22.4%
For compound 4 the middle estimate is 2.6 percentage points above the measured one; measured number inside the range.
By their numbers in this assay, from the lowest: compounds 3 and 4 (each within the scatter of the next); then compound 2; then compound 1.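

In this assay, the 3,4-dichlorophenyl group on the amide-type nitrogen shows that a low number at this position does not require trifluoromethyl: the exchange gives a number 33.9 percentage points lower from compound 2 to compound 4 (beyond the scatter) and a number 53.4 percentage points lower from compound 1 to compound 4 (beyond the scatter), both large steps. Set against the 3-(trifluoromethyl)phenyl group, the exchange gives a number 9.3 percentage points higher from compound 3 to compound 4 (within the scatter), so these two aryl groups cannot be told apart in this assay. Nothing available explains why either group differs from phenyl or 4-methylphenyl.

From the compounds shown here alone, it remains open whether 4-chlorophenyl, with one chlorine in place of two, would keep this level, and whether a methoxy or nitrile group on the ring would do the same. Going by these compounds, how a carboxylic acid or an amine on this aryl ring would fare also remains open.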